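A few compounds are considered here, and "the series" means these few. Any claim that something is new, unique, unknown or untested is made for them only; others in the source may bear on it.

Working notes on the series. In a functional assay on DU-145 cells (Homo sapiens) for cytotoxicity, read by sulforhodamine B assay, with a stated time of 48 h (a higher number here means a weaker inhibitor, a lower number a stronger inhibitor), compound 1 `C[C@H]1CC[C@@H]2[C@@H](OC(=O)[C@]23CC(c2ccc(O)cc2)=NO3)[C@]2(C)C(=O)C=C[C@@]12O` gives 93000 nM and compound 2 `C[C@H]1CC[C@@H]2[C@@H](OC(=O)[C@]23CC(c2cccc([N+](=O)[O-])c2)=NO3)[C@]2(C)C(=O)C=C[C@@]12O` gives 51000 nM. Among the compounds with values here, compound 2 therefore stands level with compound 1 on the only two numbers available, since the gap between them lies within the scatter.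

Compound 3 `Cc1ccc(C2=NO[C@]3(C2)C(=O)O[C@@H]2[C@H]3CC[C@H](C)[C@]3(O)C=CC(=O)[C@@]23C)cc1` keeps the core of compound 2 and differs at one place: 4-methylphenyl in place of 3-nitrophenyl on a carbon with a double bond to nitrogen. The change is 4-methylphenyl in place of 3-nitrophenyl on a carbon with a double bond to nitrogen.

Within the data shown here, one measured step bears on it, an exchange on that same carbon: a 1.8-fold lower number from compound 1 to compound 2 (0.26 log units; within the scatter). Among the measured compounds shown here, that single step, within the scatter, is thin evidence, and no compound with 4-methylphenyl has been measured yet. For the measured compounds named here, still, the one exchange seen at this place moved the number by no more than the scatter, so no step beyond the scatter is expected in this assay. The estimated step is a 1.3-fold higher number from compound 2 to compound 3 (0.11 log units; within the scatter), with no firm direction expected. For compound 3 the expected value is 65000 nM, with an estimated range of 30000 nM to 130000 nM.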

Compound 3, half-maximal inhibitory concentration: 14000 nM
Compound 3: the middle estimate sits 4.6-fold (0.67 log units) above what was measured; measured number below the stated range.
By their numbers in this assay, from the lowest: compound 3; then compounds 2 and 1 (each within the scatter of the next).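

In this assay, the aryl group on the carbon with a double bond to nitrogen can move the number beyond the scatter, which the exchange between compounds 1 and 2 did not show: the change to 4-methylphenyl gives a 3.6-fold lower number from compound 2 to compound 3 (0.56 log units; beyond the scatter), a modest step. The same group also separates from the 4-hydroxyphenyl of compound 1, with methyl in place of hydroxy on an aromatic carbon giving a 6.6-fold lower number from compound 1 to compound 3 (0.82 log units; beyond the scatter), so this place responds to a small exchange on the phenyl ring while the shared core stays unchanged. No measurement at hand accounts for either step.

The step from compound 2 to compound 3 changes both the group on the phenyl ring and the number in its name, so the compounds shown do not separate these two differences. Also open, on these data alone, is whether the lower number stays with methyl alone or persists with an amine, a carboxylic acid or a longer chain in its place, since the three values give no trend that can be carried to such groups.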